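Three aryl variants at the assay limit, a fourth awaited

A few compounds are considered here, and "the series" means these few. Any claim that something is new, unique, unknown or untested is made for them only; others in the source may bear on it.

Compound 1 `C/C(=C\CC/C(C)=C/CC[C@@H]1[C@@]2(C)CCC(=O)C(C)(C)[C@H]2CC[C@@]1(C)O)CC/C=C(\C)C(=O)OCc1cn(-c2ccc(F)c(Cl)c2)nn1`: > 150000 nM
Compound 2 `C/C(=C\CC/C(C)=C/CC[C@@H]1[C@@]2(C)CCC(=O)C(C)(C)[C@H]2CC[C@@]1(C)O)CC/C=C(\C)C(=O)OCc1cn(-c2ccc(C)cc2)nn1`: > 150000 nM
Compound 3 `C/C(=C\CC/C(C)=C/CC[C@@H]1[C@@]2(C)CCC(=O)C(C)(C)[C@H]2CC[C@@]1(C)O)CC/C=C(\C)C(=O)OCc1cn(-c2ccccc2F)nn1`: > 150000 nM

In a functional assay on A549 cells (Homo sapiens) for antiproliferative activity, read by MTT assay, with a stated time of 48 h (a higher number here means a weaker inhibitor, a lower number a stronger inhibitor), compound 1 gives > 150000 nM, which is a limit of the assay and not a number. Compound 2 gives > 150000 nM, likewise a limit. Compound 3 gives > 150000 nM, also a limit. Compound 1 thus stands at the limit, as do the two other values shown: the limit of > 150000 nM in this assay, at which 3 of the 3 values shown sit.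

The three measured steps, a step that the two limits leave unreadable from compound 1 to compound 2, a step that the two limits leave unreadable from compound 1 to compound 3 and a step that the two limits leave unreadable from compound 2 to compound 3, each join two limits, so no size can be read from any of them. All three are exchanges of the aryl group on the aromatic nitrogen, the same place that is altered on the way to compound 4 `C/C(=C\CC/C(C)=C/CC[C@@H]1[C@@]2(C)CCC(=O)C(C)(C)[C@H]2CC[C@@]1(C)O)CC/C=C(\C)C(=O)OCc1cn(-c2cccc(Br)c2)nn1`: 3-bromophenyl in place of 3-chloro-4-fluorophenyl on an aromatic nitrogen. These steps bear on the change, but none gives a size, and no step beyond the scatter can be expected in either direction; the plain expectation is that compound 4 will also stop at the limit in this assay. Compound 4 is therefore estimated at 200000 nM, with a range from 100000 nM to 500000 nM. The step this estimate implies, a step that the limit leaves unreadable from compound 1 to compound 4, is expected to be no more than a move along the limit itself.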

Compound 4, half-maximal inhibitory concentration: > 150000 nM
Compound 4: a limit, no number (the forecaster's own chance of this, stated with the estimate: 85%); the middle value does not contradict the limit.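

In this assay compound 4 gives > 150000 nM, a limit of the assay and not a number. Its steps from compound 1, compound 2 and compound 3 therefore cannot be read, as all four compounds stop at the same limit: the limit of > 150000 nM in this assay, at which 4 of the 4 values shown sit.

The compounds shown leave open how the four compare with one another, and whether any other aryl group would give a measurable value.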